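Pyridin-3-yl Replaces 3-Methoxyphenyl: An Expected Binding Value

The compounds below may be only part of what the source reports. "The series", "measured", "known", "first", "only" and "open" are said of these compounds alone.

Among the compounds with values here, compound 2 `COc1cccc(-c2cc(=O)c3cc(OCCCCCCN4CCC(O)CC4)ccc3o2)c1` gives 76 nM in an assay on isolated protein (Cavia porcellus) with Sigma non-opioid intracellular receptor 1 (Homo sapiens) as the target, read by radioligand binding; on this read-out higher numbers stand for weaker inhibition and lower numbers for stronger inhibition; the only other measured compound, compound 1 `O=c1cc(-c2ccccc2Cl)oc2ccc(OCCCCCCN3CCC(O)CC3)cc12`, gives 47 nM, and the step of a 1.6-fold higher number from compound 1 to compound 2 (0.21 log units; within the scatter) lies within the scatter. Compound 3 `O=c1cc(-c2cccnc2)oc2ccc(OCCCCCCN3CCC(O)CC3)cc12` differs from compound 2 by pyridin-3-yl in place of 3-methoxyphenyl on an aromatic carbon. Within the data shown here, the single measured step at this position, which did not move beyond the scatter, is the only one bearing on this change, so no shift beyond the scatter is expected here either. For compound 3 a number around 110 nM is therefore expected, in a range from 40 nM to 300 nM. The step of a 1.4-fold higher number from compound 2 to compound 3 (0.16 log units; within the scatter) is expected to stay within the scatter.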

Compound 3, half-maximal inhibitory concentration: 194 nM
Beside the measured number, compound 3's estimate is 1.8-fold (0.25 log units) below it; the range from low to high includes it.
By their numbers in this assay, from the lowest: compounds 1 and 2 (each within the scatter of the next); then compound 3.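

In this assay this position proves sensitive to the group it carries: pyridin-3-yl gives a 2.6-fold higher number from compound 2 to compound 3 (0.41 log units; beyond the scatter) and a 4.1-fold higher number from compound 1 to compound 3 (0.62 log units; beyond the scatter) as well. Unlike the exchange of 2-chlorophenyl for 3-methoxyphenyl, both changes to pyridin-3-yl move beyond the scatter, leaving compound 3 the weakest of the three. Nothing available explains this shift. The compounds shown leave open whether the higher number goes with the ring nitrogen or with the loss of the methoxy or chloro substituent. Plain phenyl would separate these two readings, and pyridin-4-yl would show whether the nitrogen's place matters.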